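Compound 2 to compound 4: a methoxy step

The source may hold more compounds than are shown below. What is called first, only, known or untested is meant among the compounds shown, and "the series" means these compounds.

Values in a functional assay on ECa-109 cells (Homo sapiens) for antiproliferative activity, read by MTT assay, with a stated time of 48 h; on this read-out lower numbers stand for stronger inhibition and higher numbers for weaker inhibition:
- compound 1 `Cn1cc(C2=C(c3nn(CCCn4cncn4)c4ncccc34)C(=O)N(c3ccccc3)C2=O)c2ccccc21`: > 100000 nM (a limit, not a number)
- compound 2 `Cn1cc(C2=C(c3nn(CCCN4CCCCC4)c4ncccc34)C(=O)N(c3ccccc3)C2=O)c2ccccc21`: 12300 nM
- compound 3 `CN(C)CCCn1nc(C2=C(c3cn(C)c4ccccc34)C(=O)N(c3ccccc3)C2=O)c2cccnc21`: 5840 nM

Compound 2 gives 12300 nM, the higher of the two actual numbers in this assay. Among the measured compounds shown here, the only other number shows a 2.1-fold lower number from compound 2 to compound 3 (0.32 log units; beyond the scatter). The third value, for compound 1, is a limit.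

The next structure is compound 4 `COc1ccc(N2C(=O)C(c3cn(C)c4ccccc34)=C(c3nn(CCCN4CCCCC4)c4ncccc34)C2=O)cc1`, and the change is methoxy in place of hydrogen on an aromatic carbon. In short, methoxy stands in place of hydrogen on an aromatic carbon, turning phenyl into 4-methoxyphenyl.

The measured steps all change the group at the end of the saturated chain: an at least 8.1-fold lower number from compound 1 to compound 2 (0.91 log units; beyond the scatter) and an at least 17-fold lower number from compound 1 to compound 3 (1.23 log units; beyond the scatter), both resting on the limit of compound 1, plus the modest step from compound 2 given above. None of them touches the phenyl, and their sizes do not carry over to this change. No direction is therefore favoured with any confidence, and the expectation stays anchored on compound 2 at 12300 nM. The expected result in this assay is a 1.2-fold lower number from compound 2 to compound 4 (0.09 log units; within the scatter), a step not expected to go beyond the scatter. For compound 4 the estimated value is 10000 nM, with an expected range from 3500 nM to 30000 nM.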

Compound 4, half-maximal inhibitory concentration: 3340 nM
For compound 4 the middle estimate is 3.0-fold (0.48 log units) above the measured one; the measured number lies below the stated range.
By their numbers in this assay, from the lowest: compounds 4 and 3 (each within the scatter of the next); then compound 2. At a limit, above all of these: compound 1.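

In this assay, among the compounds shown here, turning phenyl into 4-methoxyphenyl gives a 3.7-fold lower number from compound 2 to compound 4 (0.57 log units; beyond the scatter), so the read-out responds to this ring as well as to the group at the end of the saturated chain, the only part that changed in the earlier steps. The change is small, a methoxy on an aromatic carbon para to a large group, yet the step lies beyond the scatter and, with the piperidin-1-yl chain held constant, belongs to this one place alone. Nothing in the data shown gives a reason for the step.

Going by these compounds, the series holds a single substituent at this place, so it remains open whether chloro, hydroxy, an amine or a carboxylic acid there would shift the number in the same direction, and whether methoxy elsewhere on the ring would do the same. On these data alone, it also remains open whether the methoxy step carries over to the dimethylamino chain of compound 3, which stands at 5840 nM with the unsubstituted phenyl, or whether it holds only with the piperidin-1-yl chain.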